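Dropping the nitro group from compound 2: an expected step

The compounds below may be only part of what the source reports. "The series", "measured", "known", "first", "only" and "open" are said of these compounds alone.

Measured so far:
compound 1, `COc1cccc2cc(-c3nn[nH]n3)cnc12`: 2.5 mg/kg
compound 2, `Cc1cc([N+](=O)[O-])c2cc(-c3nn[nH]n3)cnc2c1C`: 2.5 mg/kg
compound 3, `O=c1c(-c2nn[nH]n2)c[nH]c2c(C(F)(F)F)cccc12`: 0.156 mg/kg

All three compounds were tested in a functional assay on the whole organism (strain Sprague-Dawley) for inhibition, with Rattus norvegicus as the target; a higher number here means that more compound is needed for the effect, a lower number that less compound is needed. In this assay compound 1 gives 2.5 mg/kg and compound 2 gives 2.5 mg/kg; these two numbers agree at the digits shown and lie within the scatter of each other, so no order can be read between them, and together they are the highest of the three. Compound 3, built on a different core, gives 0.156 mg/kg, a lower number that lies well beyond the scatter from compound 2.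

The next compound, compound 4, `Cc1ccc2cc(-c3nn[nH]n3)cnc2c1C`, has not yet been measured. It differs from compound 2 in one place: hydrogen in place of nitro on an aromatic carbon. Within the data shown here, no pair of measured compounds shows this change by itself, so its effect on this assay is unknown from the numbers at hand. In the absence of such a comparison, the expectation is that the step of no change at the digits printed from compound 2 to compound 4 (within the scatter) will be small, with no clear direction beyond the scatter. Compound 4 is therefore estimated to give about 2.5 mg/kg in this assay, with a range from 1 mg/kg to 6 mg/kg.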

Compound 4, minimum effective dose: 1 mg/kg
Beside the measured number, compound 4's estimate is 2.5-fold (0.40 log units) above it, and the stated range covers the measured number.
By their numbers in this assay, from the lowest: compound 3; then compound 4; then compounds 1 and 2 (each within the scatter of the next).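

In this assay, among these compounds, this is the first change in the set that can be read by itself: a 2.5-fold lower number from compound 2 to compound 4 (0.40 log units; beyond the scatter). The step is modest, but it shows that the nitro group on this aromatic carbon, para to a methyl group, is not needed for the effect, since the compound with hydrogen there needs less compound rather than more. Nothing at hand explains why the number falls when the nitro group leaves, so the step stands as an observation only.

A single swap to hydrogen also leaves open whether the nitro group itself carries a cost or whether other groups on this carbon, such as an amine or a chlorine atom, would give a number like that of compound 2 or that of compound 4. Among the compounds shown here, it is equally open whether the same change would give a step of similar size and direction on the core of compound 1 or the core of compound 3, where no such pair is available.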